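The compounds below may be only part of what the source reports. "The series", "measured", "known", "first", "only" and "open" are said of these compounds alone.

Series notes. The shared core of compound 1 `CCSc1ccc(-c2nccc3[nH]c(C(C)(C)O)cc23)cc1` carries a para substituent on its pendant aromatic ring; in an ADME assay on U2OS cells (Homo sapiens) for cytotoxicity (a lower number here means that less compound is tolerated, a higher number that more compound is tolerated), compound 1 gives 17200 nM, the lowest of the two numbers in hand. Compound 2 `CC(C)(O)c1cc2c(-c3ccc(C(F)(F)F)cc3)nccc2[nH]1` gives 72300 nM, and the change a 4.2-fold higher number from compound 1 to compound 2 (0.62 log units; beyond the scatter) lies beyond the scatter. Compound 3 `CC(=O)c1ccc(-c2nccc3[nH]c(C(C)(C)O)cc23)cc1` gives "not determined" (no result reported) in this assay, so it adds no number. Compound 4 `CC(C)(O)c1cc2c(-c3ccccc3)nccc2[nH]1` is the unsubstituted analogue: hydrogen in place of ethylsulfanyl on an aromatic carbon. For the measured compounds named here, only the step from compound 1 to compound 2 bears on this change, and it shows that replacing ethylsulfanyl raised the number modestly. Removal to hydrogen is a different replacement, so a smaller upward shift is expected for compound 4, a 2.0-fold higher number from compound 1 to compound 4 (0.31 log units; beyond the scatter). Compound 4 is thus estimated at 35000 nM, within 12000 nM to 100000 nM.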

Compound 4, half-maximal cytotoxic concentration: 22200 nM
Compound 4: middle estimate off by 1.6-fold (0.20 log units), on the high side, within the range that was stated.
By their numbers in this assay, from the lowest: compounds 1 and 4 (each within the scatter of the next); then compound 2.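

Hydrogen in place of ethylsulfanyl on this aromatic carbon does not separate the two compounds in this assay (a 1.3-fold higher number from compound 1 to compound 4 (0.11 log units; within the scatter)). The shift seen with trifluoromethyl therefore belongs to that group rather than to the loss of ethylsulfanyl, as the step to the unsubstituted analogue also shows (a 3.3-fold lower number from compound 2 to compound 4 (0.51 log units; beyond the scatter)). No measurement at hand gives a reason for this. On these data alone, whether the higher number is particular to trifluoromethyl remains open. A nitrile, an amine or a carboxylic acid at this place could test that.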